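This account rests on a few compounds, and the source may have more. Where it says the series, first, only, none or still open, it means among the compounds named here.

Compound 1, with the structure `c1ccc(-c2ccc(-c3ccc(-c4nc5ccccc5[nH]4)cc3)cc2)cc1`, is the starting point of this small series. In a functional assay on Gurav cells (Homo sapiens) for inhibition, read by sulforhodamine B assay (on this read-out lower numbers stand for stronger inhibition of growth and higher numbers for weaker inhibition of growth), compound 1 gives 100000 nM. Compound 2, `Fc1ccc(-c2ccc(-c3ccc(-c4nc5ccccc5[nH]4)cc3)cc2)cc1`, carries the change (fluoro in place of hydrogen on an aromatic carbon), and in this assay compound 2 gives 100000 nM; the step of no change at the digits printed from compound 1 to compound 2 (within the scatter) shows that this change left the read-out where it was.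

Compound 3, `Cc1ccc2[nH]c(-c3ccc(-c4ccc(-c5ccccc5)cc4)cc3)nc2c1`, differs from compound 1 in its core, where the difference is methyl in place of hydrogen on an aromatic carbon. In this assay compound 3 gives 3310 nM, and the step of a 30-fold lower number from compound 1 to compound 3 (1.48 log units; beyond the scatter) is the only large movement among the measured compounds. Compound 3 therefore stands with the lowest number of the three, and its distance to both compound 1 and compound 2 is of the same size.

Compound 4, `Cc1ccc2[nH]c(-c3ccc(-c4ccc(-c5ccc(F)cc5)cc4)cc3)nc2c1`, has not yet been measured in this assay. It differs from compound 3 by fluoro in place of hydrogen on an aromatic carbon, which is the same change that separates compound 2 from compound 1, made at the same place, here on the core of compound 3. For the measured compounds named here, the single precedent for this change, the step of no change at the digits printed from compound 1 to compound 2 (within the scatter), was flat. On that ground the step from compound 3 to compound 4 is expected to be about a 1.1-fold higher number from compound 3 to compound 4 (0.02 log units; within the scatter), staying within the scatter. The number expected for compound 4 in this assay is therefore 3500 nM, estimated to lie from 1500 nM to 10000 nM.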

Compound 4, concentration for 50% growth inhibition: 16500 nM
The estimate for compound 4 lay 4.7-fold (0.67 log units) below the measured number, outside the stated range (above it).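

In this assay, the change from phenyl to 4-fluorophenyl on the methyl-bearing core gave a 5.0-fold higher number from compound 3 to compound 4 (0.70 log units; beyond the scatter), so the flat result of the same change on the core of compound 1 did not carry over: the same change on two cores in this assay, no change at the digits printed (within the scatter) from compound 1 to compound 2 and a 5.0-fold higher number (0.70 log units; beyond the scatter) from compound 3 to compound 4, 5.0-fold (0.70 log units) apart, beyond the scatter of two such steps. The methyl change, read on the fluorinated pair, gave a 6.1-fold lower number from compound 2 to compound 4 (0.78 log units; beyond the scatter), which keeps the direction seen without the fluoro group but not the size: the same change on two cores in this assay, a 30-fold lower number (1.48 log units; beyond the scatter) from compound 1 to compound 3 and a 6.1-fold lower number (0.78 log units; beyond the scatter) from compound 2 to compound 4, 5.0-fold (0.70 log units) apart, beyond the scatter of two such steps. These two gaps are the same four compounds read in two ways, so they show that in this set the effect of each change depends on whether the other is present, but they do not show why, nor how either change would behave on any further core.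

The compounds shown leave open whether a chloro atom, a methoxy group or an amine in place of that same hydrogen would follow the fluoro group on either core. They also leave open whether an ethyl group or a carboxylic acid in place of the methyl group on the core would give a step like the one seen with methyl.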